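Swapping an Amino Group for Methoxy: an Estimate

A few compounds are considered here, and "the series" means these few. Any claim that something is new, unique, unknown or untested is made for them only; others in the source may bear on it.

Compound 1, `COc1ccc(-n2cc(-c3ccc(N)cc3)nn2)cc1O`, in a functional assay on MDA-MB-231 cells (Homo sapiens) for cytotoxicity, read by MTT assay (a higher number here means a weaker inhibitor, a lower number a stronger inhibitor), compound 1 gives > 10000 nM, a limit of the assay rather than a number.
Compound 2, `COc1ccc(-c2cn(-c3ccc(OC)c(O)c3)nn2)cc1`, in this assay compound 2 gives > 100 nM, again a limit and not a number.
Compound 3, `COc1ccc(-n2cc(-c3ccc(N)cc3)nn2)c(OC)c1`, in this assay compound 3 gives > 10000 nM, also only a limit.

The change from compound 1 to compound 2 is methoxy in place of amino on an aromatic carbon, and its size is a step that the two limits leave unreadable from compound 1 to compound 2. It stays unreadable because the limit of > 100 nM in this assay, at which 1 of the 3 values shown sits, and the limit of > 10000 nM in this assay, at which 2 of the 3 values shown sit, bound what the two values can show. Compound 3 carries a different core from compound 1; the difference between the two cores is not broken down here.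

Compound 4, `COc1ccc(-c2cn(-c3ccc(OC)cc3OC)nn2)cc1`, is not yet measured. It differs from compound 3 by methoxy in place of amino on an aromatic carbon, the same change seen between compound 1 and compound 2. For compound 4 the expected step is a number no higher from compound 3 to compound 4 (the limit leaves the size open), resting only on the fact that compound 3 sits at a limit and on the earlier unreadable step that the two limits leave unreadable from compound 1 to compound 2, so the expectation is loose. The estimate for compound 4 in this assay is 10000 nM, expected between 1000 nM and 100000 nM.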

Compound 4, half-maximal inhibitory concentration: > 10000 nM
Compound 4: a limit, no number (the forecaster's own chance of this, stated with the estimate: 60%); the middle value lies on the limit itself.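

In this assay, compound 3 and compound 4 each give only a limit of the assay rather than a number, so no size can be read for the step between them: the limit of > 10000 nM in this assay, at which 3 of the 4 values shown sit.

The compounds shown leave open whether methoxy in place of amino on an aromatic carbon changes the cytotoxicity at all, and by how much.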